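This account rests on a few compounds, and the source may have more. Where it says the series, first, only, none or still open, it means among the compounds named here.

Measured compounds in a toxicity assay on THP-1 cells (Homo sapiens) for inhibition; a higher number here means that more compound is tolerated, a lower number that less compound is tolerated:
- Compound 1 `COc1ccc(-c2cnc(NC(=O)c3cccc(OC)c3)n2C)cc1` gives > 100000 nM, a limit of the assay.
- Compound 2 `COc1ccc(-c2cnc(NC(=O)c3ccn[nH]3)n2C)cc1` gives > 100000 nM, a limit of the assay.
- Compound 3 `COc1ccc(-c2cnc(NC(=O)c3cnco3)n2C)cc1` gives > 100000 nM, a limit of the assay.

Compound 3 stands at the upper limit of this assay, and no number is known for it; the same holds for the two other values shown, since (the limit of > 100000 nM in this assay, at which 3 of the 3 values shown sit). Compound 4 `COc1ccc(-c2cnc(NC(=O)c3ccccc3Br)n2C)cc1` differs from compound 3 as follows: 2-bromophenyl in place of 1,3-oxazol-5-yl on a carbonyl carbon.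

The steps already measured all change the group on the carbonyl carbon, which is the same place touched here: a step that the two limits leave unreadable from compound 1 to compound 2, a step that the two limits leave unreadable from compound 1 to compound 3 and a step that the two limits leave unreadable from compound 2 to compound 3. None of them gives a readable size, so they carry no information on direction or magnitude beyond showing that three different groups at this position all stayed at the limit.

Compound 4 is therefore expected to sit at 100000 nM, with a range of 30000 nM to 300000 nM. The expected step is a number no higher from compound 3 to compound 4 (the limit leaves the size open), most likely again reported as a limit rather than a number.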

Compound 4, half-maximal cytotoxic concentration: > 100000 nM
Compound 4: only a limit was reported (the forecaster's own chance of this, stated with the estimate: 75%); the middle value sits exactly at the limit.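

In this assay compound 4, like compound 1, compound 2 and compound 3, gives only a limit and not a number, so no step among them can be read: the limit of > 100000 nM in this assay, at which 4 of the 4 values shown sit.

The compounds shown leave open at what concentration any of them becomes toxic, and whether the group on the carbonyl carbon changes that concentration.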